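Methoxy on the aryl ring of a spirocyclic sigma ligand

The source may hold more compounds than are shown below. What is called first, only, known or untested is meant among the compounds shown, and "the series" means these compounds.

Three compounds from one series were measured in an assay on membranes from brain for displacement of a labelled ligand from Sigma non-opioid intracellular receptor 1 (Cavia porcellus), read by scintillation counting, with a stated time of 120 min; on this read-out higher numbers stand for weaker inhibition and lower numbers for stronger inhibition. Compound 2 `c1ccc(CN2CCC3(CC2)OCCc2c(-c4ccccc4)csc23)cc1` gives 1.6 nM, compound 1 `Cc1ccc(-c2scc3c2CCOC32CCN(Cc3ccccc3)CC2)cc1` gives 3.6 nM, and compound 3 `COC1Cc2c(-c3ccccc3)csc2C2(CCN(Cc3ccccc3)CC2)O1` gives 5.4 nM. Compound 3 therefore has the highest of the three numbers; it sits within the scatter of compound 1, while the step of a 3.4-fold higher number from compound 2 to compound 3 (0.53 log units; beyond the scatter) lies beyond it. Compound 1 and compound 2, which differ by a methyl group on the aromatic ring, show values that are separated only modestly.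

Compound 4 `COc1ccc(-c2csc3c2CC(OC)OC32CCN(Cc3ccccc3)CC2)cc1` is not yet measured. It differs from compound 3 by methoxy in place of hydrogen on an aromatic carbon: the new group sits on an aromatic carbon of a six-membered aromatic ring of carbon only, para to a large group. Going by the values given here, no measured step involves a methoxy group at this aromatic position; the only methoxy step available, a 3.4-fold higher number from compound 2 to compound 3 (0.53 log units; beyond the scatter), concerns a saturated ring carbon, and so bears on the present change only loosely. The methyl substitution seen between compound 2 and compound 1 suggests that a small group at this ring does not move the number far.

The step of a 1.5-fold higher number from compound 3 to compound 4 (0.17 log units; within the scatter) is therefore expected to be small, probably within the scatter, with a slight lean toward a higher number. For compound 4 the estimate in this assay is 8 nM, with a range from 3 nM to 25 nM.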

Compound 4, inhibition constant: 7.1 nM
Beside the measured number, compound 4's estimate is 1.1-fold (0.05 log units) above it, and the stated range covers the measured number.
By their numbers in this assay, from the lowest: compound 2; then compounds 1, 3 and 4 (each within the scatter of the next).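

In this assay the change from phenyl to 4-methoxyphenyl gives a 1.3-fold higher number from compound 3 to compound 4 (0.12 log units; within the scatter) and so stays within the scatter. Going by these compounds alone, this is the first reading of a methoxy group on an aromatic carbon of this six-membered ring, para to a large group, and the number for the methoxy compound cannot be told apart from the number for the compound with hydrogen there, on a background that already carries methoxy on a saturated ring carbon. Nothing available explains this result, and no measurement beyond the binding numbers bears on it.

The compounds shown leave open whether the same change would read the same way on compound 2, which has no methoxy on the saturated ring carbon, since only the background of compound 3 has been read for this change. Within the data shown here, they also leave open how this place would respond to a group unlike methoxy, such as a primary amine, a carboxylic acid or a longer chain like butoxy, as the only groups seen on this ring are methyl and methoxy.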